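A few compounds are considered here, and "the series" means these few. Any claim that something is new, unique, unknown or untested is made for them only; others in the source may bear on it.

Measured so far:
compound 1 `Cc1ccc(C(=O)CCN2CCN(c3ccc([N+](=O)[O-])cc3)CC2)cc1`: 235000 nM
compound 2 `O=C(CCN1CCN(c2ccc([N+](=O)[O-])cc2)CC1)c1ccc(F)c(Br)c1`: 256000 nM

In an ADME assay on Vero cells (Chlorocebus sabaeus) for cytotoxicity, read by resazurin assay, with a stated time of 72 h (a lower number here means a stronger inhibitor, a higher number a weaker inhibitor), compound 2 gives 256000 nM, a number that cannot be told apart from that of compound 1. Going by the values given here, the one measured step, a 1.1-fold higher number from compound 1 to compound 2 (0.04 log units; within the scatter), put 3-bromo-4-fluorophenyl in place of 4-methylphenyl on a carbonyl carbon and stayed within the scatter. Compound 3 `O=C(CCN1CCN(c2ccc([N+](=O)[O-])cc2)CC1)c1ccc(F)c(F)c1` carries fluoro in place of bromo on an aromatic carbon. Among the compounds with values here, with that single step as the only guide, no change beyond the scatter is expected in this assay. The expected move is a 1.1-fold lower number from compound 2 to compound 3 (0.03 log units; within the scatter). For compound 3 the estimated value is 240000 nM, with a range of 120000 nM to 420000 nM.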

Compound 3, half-maximal inhibitory concentration: 122000 nM
Beside the measured number, compound 3's estimate is 2.0-fold (0.29 log units) above it; measured number inside the range.
By their numbers in this assay, from the lowest: compounds 3, 1 and 2 (each within the scatter of the next, the first and the last beyond it).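

In this assay this place on the aromatic ring proves responsive to the exchange of halogens: fluoro in place of bromo gives a 2.1-fold lower number from compound 2 to compound 3 (0.32 log units; beyond the scatter) as a modest step, the first here beyond the scatter. Set against the 4-methylphenyl of compound 1, the 3,4-difluorophenyl of compound 3 gives a 1.9-fold lower number from compound 1 to compound 3 (0.28 log units; within the scatter) and stays within the scatter. Nothing shown supplies a reason for the step. From the compounds shown here alone, whether chloro or methoxy at this place would track fluoro or bromo remains open, as does the effect of replacing the nitro group with an amine or a carboxylic acid.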